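The compounds below may be only part of what the source reports. "The series", "measured", "known", "first", "only" and "open" are said of these compounds alone.

Three esters on the shared core have been measured. Compound 1 `CC(C)=CCC/C(C)=C/CC/C(C)=C/CC[C@]1(C)CCc2c(C)c(OC(=O)c3cc(C(=O)O)ccc3C(=O)O)c(C)c(C)c2O1` gives 50% in a functional assay on MDA-MB-231 cells (Homo sapiens), read by wound healing assay, with a stated time of 24 h, tested at 5 uM; on this read-out higher numbers stand for more inhibition at the one concentration tested (going by the name of the read-out) and lower numbers for less inhibition. Compound 2 `CC(C)=CCC/C(C)=C/CC/C(C)=C/CC[C@]1(C)CCc2cc(OC(=O)c3cc(C(=O)O)ccc3C(=O)O)cc(C)c2O1` gives 50% in this assay, and compound 3 `CC(C)=CCC/C(C)=C/CC/C(C)=C/CC[C@]1(C)CCc2cc(OC(=O)/C=C\C(=O)O)c(C)c(C)c2O1` gives 50% in this assay. Compound 3 thus stands level with compound 1 and compound 2, all within the scatter; none of the three separates from the others. Compound 4 `CC(C)=CCC/C(C)=C/CC/C(C)=C/CC[C@]1(C)CCc2cc(OC(=O)c3ccccc3)c(C)c(C)c2O1` differs from compound 3 in one place: phenyl in place of 2-carboxyethenyl on a carbonyl carbon. Going by the values given here, no measured pair carries this kind of change, so nothing anchors it directly. Since the three measured esters sit together, the step of no change at the digits printed from compound 3 to compound 4 (within the scatter) is expected to be none beyond the scatter. Compound 4 is estimated at 50% in this assay, within 30% to 65%.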

Compound 4, a percentage reported as inhibition, at one concentration (the size of the read-out at that concentration, not a potency): 50%
Estimate against measurement, compound 4: no gap at the digits printed, and the stated range covers the measured number.
By their numbers in this assay, from the lowest: compounds 1, 2, 3 and 4 (each within the scatter of the next).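

In this assay, going by these compounds alone, the change to phenyl in place of 2-carboxyethenyl on a carbonyl carbon gives no change at the digits printed from compound 3 to compound 4 (within the scatter) and is the first one-place step. Compound 1, compound 2 and compound 3 all carry a carboxylic acid in the ester group, whereas compound 4 has none there, and for this pair the read-out does not register its loss. Nothing on hand accounts for this result.

As far as these compounds go, an amine or a longer alkyl chain on this carbonyl carbon remains open. Any potency differences among these esters also remain open, as the read-out comes from one concentration.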